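Trading a hydroxy group for hydrogen in compound 4

The source may hold more compounds than are shown below. What is called first, only, known or untested is meant among the compounds shown, and "the series" means these compounds.

Of the compounds shown here, three have been measured in an assay on HEK293 cells for agonist activity at transient receptor potential cation channel subfamily M member 8 (Homo sapiens), read by fluorescence and calcium flux, with a stated time of 15 min; on this read-out higher numbers stand for an effect only at larger amounts of compound and lower numbers for an effect already at smaller amounts. Compound 1 `CCN(Cc1cccs1)C(=O)COc1ccc(Cl)cc1` gives 39 nM, compound 2 `CCN(Cc1ccsc1)C(=O)COc1ccc(C)cc1` gives 88 nM, and compound 3 `CCN(Cc1cccs1)C(=O)COc1cc(C)ccc1O` gives 24 nM. Compound 3 carries the lowest number of the three; its gap to compound 1 lies within the scatter, so no order can be read between those two, while its gap to compound 2 lies beyond the scatter. Compound 4 `CCN(Cc1cccs1)C(=O)COc1cccc(C)c1` differs from compound 3 in one place: hydrogen in place of hydroxy on an aromatic carbon. Among the compounds with values here, no measured pair shows this change, so its size is unknown. The writer expects a small shift toward a higher number, a 1.7-fold higher number from compound 3 to compound 4 (0.22 log units; within the scatter), possibly none beyond the scatter. Compound 4 is accordingly estimated at 40 nM, with a range from 15 nM to 110 nM.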

Compound 4, half-maximal effective concentration: 97 nM
For compound 4 the middle estimate is 2.4-fold (0.38 log units) below the measured one, and the stated range covers the measured number.
By their numbers in this assay, from the lowest: compounds 3 and 1 (each within the scatter of the next); then compounds 2 and 4 (each within the scatter of the next).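

In this assay, hydrogen in place of hydroxy on this aromatic carbon, ortho to a large group and para to a methyl group, gives a 4.0-fold higher number from compound 3 to compound 4 (0.61 log units; beyond the scatter) and so puts a first size on this change. The hydroxy thus goes with the lower number in this one pair, though a single pair cannot show how general that is. Nothing shown gives a reason for the step. From the compounds shown here alone, whether a methoxy group, fluorine or an amine at this place would give a number like that of compound 3 stays open. Also open, going by these compounds, is whether the step keeps its size when chlorine replaces the methyl group.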